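Turning the stereocentre in a chlorinated aryloxy amine

This account rests on a few compounds, and the source may have more. Where it says the series, first, only, none or still open, it means among the compounds named here.

Two members of this series have been measured in an assay on isolated protein for inhibition of sodium channel protein type 4 subunit alpha (Homo sapiens); a lower number here means that less compound is needed, a higher number that more compound is needed for the effect. Compound 1, `Cc1cccc(C)c1OC[C@@H](N)c1ccccc1`, gives 3020 nM. Compound 2, `Cc1cc(Cl)cc(C)c1OC[C@H](N)c1ccccc1`, gives 19500 nM, the higher of the two numbers, and the gap to compound 1 is beyond the usual scatter. Compound 3, `Cc1cc(Cl)cc(C)c1OC[C@@H](N)c1ccccc1`, has not yet been measured. It differs from compound 2 as follows: the two compounds have the same atoms and bonds and differ only in configuration as drawn: 1 of 1 stereo elements differ; a stereocentre at a saturated chain carbon is drawn R in compound 2 and S in compound 3. Compound 3 thus carries the configuration drawn for compound 1 while keeping the ring chlorine of compound 2. Since compound 1 with the same drawn configuration gives 3020 nM, compound 3 is expected to come in at a lower number than compound 2, a step of a 3.9-fold lower number from compound 2 to compound 3 (0.59 log units; beyond the scatter) in this assay, though the chlorine makes the size uncertain. The estimate for compound 3 is 5000 nM, with a range from 1500 nM to 20000 nM.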

Compound 3, half-maximal effective concentration: 7940 nM
Compound 3: the middle estimate sits 1.6-fold (0.20 log units) below what was measured, within the range that was stated.
By their numbers in this assay, from the lowest: compound 1; then compound 3; then compound 2.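

With the chlorine held in place, this assay shows a 2.5-fold lower number from compound 2 to compound 3 (0.39 log units; beyond the scatter), so the configuration at the saturated chain carbon matters on its own in this series, and the cause of this modest step can be narrowed to that single stereocentre: the fact that compounds 2 and 3 differ only in the configuration as drawn

At the same drawn S configuration, chloro in place of hydrogen on an aromatic carbon gives a 2.6-fold higher number from compound 1 to compound 3 (0.42 log units; beyond the scatter), which is also modest and beyond the scatter. The chlorine therefore does not account for the whole of the difference among these compounds, and neither does the stereocentre.

As far as these compounds go, whether the drawn S configuration also gives the lower number when the ring carries hydrogen instead of chlorine remains open. So does whether a fluorine or a methoxy group in place of the chlorine would shift the number in the same direction.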